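Pyridinyl amide variation in a kinase series

A few compounds are considered here, and "the series" means these few. Any claim that something is new, unique, unknown or untested is made for them only; others in the source may bear on it.

Compound 3 `CN(C)Cc1sc(NC(=O)c2ccncc2)nc1-c1cccnc1` gives 35.3% in an assay on isolated protein for inhibition of Rho-associated protein kinase 2 (Homo sapiens), read by ELISA, with a stated time of 30 min, tested at 10 uM, in the presence of a further agent that is not named here (on this read-out lower numbers stand for less inhibition and higher numbers for more inhibition at the one concentration tested (going by the name of the read-out)), the lowest of the three numbers; compound 2 `CN(C)C(=O)Cc1sc(NC(=O)c2ccncc2)nc1-c1ccncc1` with 38.1% stands within the scatter of it, while compound 1 `CN(C)C(=O)Cc1sc(NC(=O)C2COc3ccccc3O2)nc1-c1ccncc1` with 56.9% lies beyond it. Within the data shown here, the only measured step on the carbonyl carbon is a number 18.8 percentage points lower from compound 1 to compound 2 (beyond the scatter), a modest loss. Compound 4 `CN(C)Cc1sc(NC(=O)c2cccnc2)nc1-c1cccnc1` differs from compound 3 by pyridin-3-yl in place of pyridin-4-yl on a carbonyl carbon. Among the measured compounds shown here, no measured step exchanges one pyridinyl for another on the carbonyl carbon, so the size of such a change is unknown here; the single step at that place was only modest. For compound 4 a step of a number 4.3 percentage points lower from compound 3 to compound 4 (within the scatter) is expected, within the scatter. Compound 4 is therefore estimated at 31%, with a range of 16% to 46%.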

Compound 4, a percentage reported as inhibition, at one concentration (the size of the read-out at that concentration, not a potency): 33.9%
Compound 4: middle estimate off by 2.9 percentage points, on the low side; the range from low to high includes it.
By their numbers in this assay, from the lowest: compounds 4, 3 and 2 (each within the scatter of the next); then compound 1.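

In this assay, pyridin-3-yl in place of pyridin-4-yl on a carbonyl carbon gives a number 1.4 percentage points lower from compound 3 to compound 4 (within the scatter), so this assay does not separate the two pyridinyl amides at the one concentration tested. Among these compounds, this is the first exchange of one pyridinyl for another at this place; the earlier step there, from 2,3-dihydro-1,4-benzodioxin-2-yl to pyridin-4-yl, lay beyond the scatter. No evidence is available that bears on this result. Open, on these data alone, is whether pyridin-2-yl, or a saturated amine such as piperidin-4-yl, on the same carbonyl carbon would also leave the number within the scatter.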